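This account rests on a few compounds, and the source may have more. Where it says the series, first, only, none or still open, it means among the compounds named here.

Measured compounds in a functional assay on HeLa cells (Homo sapiens) for inhibition, read by MTT assay, with a stated time of 72 h; on this read-out lower numbers stand for stronger inhibition and higher numbers for weaker inhibition:

Compound 1 `O=c1cc(Cn2cc(CCCCl)nn2)c2ccc(O)cc2o1` gives 49600 nM.
Compound 2 `O=c1cc(Cn2cc(CCCCO)nn2)c2ccc(O)cc2o1` gives only the assay limit, > 100000 nM.
Compound 3 `CCCCCCc1cn(Cc2cc(=O)oc3cc(O)ccc23)nn1` gives 59000 nM.

Compound 3 holds the higher of the two numbers read in this assay, but the gap to compound 1, a 1.2-fold higher number from compound 1 to compound 3 (0.08 log units; within the scatter), is within the scatter, so the two cannot be ordered. Compound 2 contributes a limit only (the limit of > 100000 nM in this assay, at which 1 of the 3 values shown sits); the steps of an at least 2.0-fold higher number from compound 1 to compound 2 (0.30 log units; that floor lies within the scatter) and an at least 1.6-fold lower number from compound 2 to compound 3 (0.22 log units; that floor lies within the scatter) therefore carry only a floor, and that floor also lies within the scatter.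

Compound 4 `O=c1cc(Cn2cc(CSC(=S)N3CCOCC3)nn2)c2ccc(O)cc2o1` differs from compound 3 by a group of 9 heavy atoms (5 carbon, 1 nitrogen, 1 oxygen, 2 sulfur; one six-membered non-aromatic ring with 2 hetero atoms) in place of a group of 5 heavy atoms (5 carbon; no ring), on a saturated chain carbon bound to an aromatic carbon. Among the compounds with values here, none of the measured steps covers a change of this kind: the three steps seen concern the chain end three or four bonds along from the aromatic carbon, and all stayed within the scatter. The change to compound 4 is larger and carries in the thiocarbonyl and the ring, for which no comparison exists here. In the absence of any step beyond the scatter in the series, the expected step for compound 4 is a 1.2-fold lower number from compound 3 to compound 4 (0.07 log units; within the scatter), i.e. nothing beyond the scatter, with wide uncertainty. Compound 4 is thus estimated at 50000 nM in this assay, within 15000 nM to 150000 nM.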

Compound 4, half-maximal inhibitory concentration: 40800 nM
The estimate for compound 4 lay 1.2-fold (0.09 log units) above the measured number; the range from low to high includes it.
By their numbers in this assay, from the lowest: compounds 4, 1 and 3 (each within the scatter of the next). At a limit, above all of these: compound 2.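

In this assay, this position on a saturated chain carbon bound to an aromatic carbon accepts the group of 9 heavy atoms, with its six-membered non-aromatic ring, in place of pentyl with no readable change: a 1.4-fold lower number from compound 3 to compound 4 (0.16 log units; within the scatter), and the comparison with the chloro chain gives a 1.2-fold lower number from compound 1 to compound 4 (0.08 log units; within the scatter). Within the data shown here, the one step here that clears the scatter is an at least 2.4-fold lower number from compound 2 to compound 4 (0.38 log units; beyond the scatter), and it sets the new group apart only from the hydroxy-ended chain. Compound 2 stands at a limit, so this step gives a floor and no true size: the limit of > 100000 nM in this assay, at which 1 of the 4 values shown sits.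

Open, going by these compounds, is whether the six-membered ring alone or the thiocarbonyl alone would give the same number. Also open, on these data alone, is whether an amine or a carboxylic acid on this chain would give a step beyond the scatter from compound 3.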